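The source may report more compounds than this note shows. Statements on the series, on what has been measured and on what is new or still open speak of the compounds shown alone.

Measured compounds:
- compound 1 `Cc1nc(Nc2cccc(Cl)c2)sc1C(=O)/C=C/c1ccccc1`; in a functional assay on Bel-7402 cells (Homo sapiens) for cytotoxicity, read by MTT assay (on this read-out higher numbers stand for weaker inhibition and lower numbers for stronger inhibition), compound 1 gives > 25000 nM, which is a limit of the assay rather than a number.
- compound 2 `Cc1nc(Nc2ccc(Cl)c(Cl)c2)sc1C(=O)/C=C/c1ccccc1`; in this assay compound 2 gives 21500 nM.

Within the data shown here, compound 2 holds the only number; the other value is a limit. The step of an at least 1.1-fold lower number from compound 1 to compound 2 (0.06 log units; that floor lies within the scatter) rests on the limit of > 25000 nM in this assay, at which 1 of the 2 values shown sits, and stays within the scatter, so it fixes no direction.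

Compound 3 `COc1ccc(/C=C/C(=O)c2sc(Nc3ccc(Cl)c(Cl)c3)nc2C)cc1` differs from compound 2 by methoxy in place of hydrogen on an aromatic carbon. Among the measured compounds shown here, no measured step touches that ring or that group; the single measured step concerns chloro on the other ring and lies within the scatter. Nothing in the series therefore points to a change beyond the scatter in this assay for this step, and the expectation is a 1.1-fold lower number from compound 2 to compound 3 (0.03 log units; within the scatter). For compound 3 the estimated value in this assay is 20000 nM, with a range from 8000 nM to 50000 nM, and a fair chance that only a limit is reported.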

Compound 3, half-maximal inhibitory concentration: > 25000 nM
Compound 3 was reported as a limit; the forecaster's own chance of this, stated with the estimate: 40%; at least 1.2-fold (0.09 log units) between middle value and limit.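

Phenyl to 4-methoxyphenyl is the first change at this ring in the series, and in this assay it reads as an at least 1.1-fold higher number from compound 2 to compound 3 (0.06 log units; that floor lies within the scatter). Methoxy at this place, para to a large group, therefore shows no measurable gain over hydrogen, though neither a loss nor a direction is fixed by this step. Compound 3 gives only a limit, so compound 2 still holds the one number in the series, and the readings now gather at the same point: the limit of > 25000 nM in this assay, at which 2 of the 3 values shown sit.

Going by these compounds, whether methoxy moves the number in either direction at all remains open, as the read-out does not resolve anything on the weaker side of that limit. Also open, on these data alone, is whether an amine, a carboxylic acid or a longer chain such as butoxy on this ring would give a number clear of the scatter.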